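A Chlorophenylcarbamoylamino Extension Replacing a Hydroxyphenyl Urea Terminus

The source may report more compounds than this note shows. Statements on the series, on what has been measured and on what is new or still open speak of the compounds shown alone.

Three ureas built on a shared core have been measured in a functional assay on MIA PaCa-2 cells (Homo sapiens) for inhibition, read by MTT assay, with a stated time of 72 h; a higher number here means a weaker inhibitor, a lower number a stronger inhibitor. Compound 1 `COc1cc(NC(C)CCCNC(=O)Nc2ccc(F)cc2)c2ncccc2c1` gives 21000 nM, compound 2 `COc1cc(NC(C)CCCNC(=O)Nc2ccc(O)cc2)c2ncccc2c1` gives 57000 nM, and compound 3 `COc1cc(NC(C)CCCNC(=O)Nc2cccc(Cl)c2)c2ncccc2c1` gives 21000 nM. Compound 2 thus stands highest of the three, with a 2.7-fold higher number from compound 1 to compound 2 (0.43 log units; beyond the scatter) and a 2.7-fold lower number from compound 2 to compound 3 (0.43 log units; beyond the scatter), while no change at the digits printed from compound 1 to compound 3 (within the scatter). Compound 4 `COc1cc(NC(C)CCCNC(=O)NNC(=O)Nc2ccc(Cl)cc2)c2ncccc2c1` differs from compound 2 by ((4-chlorophenyl)carbamoyl)amino in place of 4-hydroxyphenyl on an amide-type nitrogen. For the measured compounds named here, the only steps that bear on it are those leaving the 4-hydroxyphenyl terminus, which both lowered the number modestly, yet no measured pair tests the added urea-type extension itself. A modest lowering is expected, as a 2.3-fold lower number from compound 2 to compound 4 (0.36 log units; beyond the scatter), with wide uncertainty. Compound 4 is estimated at 25000 nM, within 8000 nM to 70000 nM.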

Compound 4, half-maximal inhibitory concentration: >= 250000 nM
Compound 4: no number, only a limit (the forecaster's own chance of this, stated with the estimate: 10%); middle value at least 10-fold (1.00 log units) from the limit.
By their numbers in this assay, from the lowest: compounds 1 and 3 (each within the scatter of the next); then compound 2. At a limit, above all of these: compound 4.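

Compound 4 stands at a limit of the assay, not at a number: the limit of >= 250000 nM in this assay, at which 1 of the 4 values shown sits. On this amide-type nitrogen, ((4-chlorophenyl)carbamoyl)amino raises the number in every comparison: an at least 4.3-fold higher number from compound 2 to compound 4 (0.64 log units; beyond the scatter), an at least 11-fold higher number from compound 3 to compound 4 (1.07 log units; beyond the scatter) and an at least 11-fold higher number from compound 1 to compound 4 (1.07 log units; beyond the scatter). The earlier changes of the aromatic terminus gave modest steps at most, so this position can also carry a far larger penalty, which appears once the urea-type extension enters.

The compounds shown leave open whether the penalty follows the extension or the 4-chloro substituent. A plain 4-chlorophenyl or a benzyl group on this nitrogen would bear on that question.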